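Trifluoromethyl for Methoxy on the Aryl Ring

This account rests on a few compounds, and the source may have more. Where it says the series, first, only, none or still open, it means among the compounds named here.

Three compounds share one core. In a functional assay on CHO cells for agonist activity at metabotropic glutamate receptor 5 (Homo sapiens), read by inositol phosphate accumulation (on this read-out lower numbers stand for stronger inhibition and higher numbers for weaker inhibition), compound 1 `Cc1nc(C#Cc2ccc(F)cc2)cs1` gives 2970 nM, compound 2 `COc1cccc(C#Cc2csc(C)n2)c1` gives 49 nM, and compound 3 `COc1ccccc1C#Cc1csc(C)n1` gives 36.3 nM. Compound 2 holds the second highest of the three numbers; the number of compound 3 lies within the usual scatter of it, while the number of compound 1 lies far beyond the scatter on the higher, weaker side. Compound 4 `Cc1nc(C#Cc2cccc(C(F)(F)F)c2)cs1` has not yet been measured in this assay. It differs from compound 2 in one place: trifluoromethyl in place of methoxy on an aromatic carbon. Among the compounds with values here, no measured pair shows this exact change, so the step is expected to stay small, with no clear direction beyond the scatter, an estimated 1.1-fold higher number from compound 2 to compound 4 (0.05 log units; within the scatter). Compound 4 is expected to give about 55 nM, in a range from 15 nM to 250 nM.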

Compound 4, half-maximal inhibitory concentration: 413 nM
For compound 4 the middle estimate is 7.5-fold (0.88 log units) below the measured one; the whole stated range lies below it.
By their numbers in this assay, from the lowest: compounds 3 and 2 (each within the scatter of the next); then compound 4; then compound 1.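

Trifluoromethyl in place of methoxy on this aromatic carbon gives an 8.4-fold higher number from compound 2 to compound 4 (0.93 log units; beyond the scatter) in this assay, the first single-place change in this set, so the group at this carbon clearly matters for the read-out. The swap also removes the one hydrogen-bond acceptor of methoxy and adds heavy atoms, and nothing available separates these two differences or otherwise explains the loss. The compounds shown leave open how an amine, a hydroxyl or an ethoxy group on this carbon would compare with methoxy.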